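The compounds below may be only part of what the source reports. "The series", "measured", "known", "first", "only" and "open" are said of these compounds alone.

In a functional assay on HEp-2 cells (Homo sapiens) for cytotoxicity, read by MTT assay, with a stated time of 72 h (a higher number here means a weaker inhibitor, a lower number a stronger inhibitor), compound 1 `Cc1cc(C)nc(SCc2cc(=O)c3ccccc3o2)n1` gives only a limit, > 25000 nM. Compound 2 `Nc1nc(SCc2coc3ccccc3c2=O)n[nH]1` is measured as a number in this assay, giving 21300 nM. Compound 2 therefore holds the only number shown, the other value being (the limit of > 25000 nM in this assay, at which 1 of the 2 values shown sits). Compound 3 `Cc1nnc(SCc2coc3ccccc3c2=O)s1` differs from compound 2 by 5-methyl-1,3,4-thiadiazol-2-yl in place of 5-amino-1H-1,2,4-triazol-3-yl on a sulfur whose other neighbours are a saturated chain carbon. For the measured compounds named here, no step between measured compounds is available, so the change has nothing measured to be judged by. The step from compound 2 to compound 3 in this assay is expected to be a 1.0-fold higher number from compound 2 to compound 3 (0.01 log units; within the scatter), which is no more than the scatter of repeated measurements. Compound 3 is accordingly estimated to give about 22000 nM in this assay, within a range from 8000 nM to 60000 nM.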

Compound 3, half-maximal inhibitory concentration: 2900 nM
For compound 3 the middle estimate is 7.6-fold (0.88 log units) above the measured one; measured number outside the range, below it.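

In this assay, for the compounds shown here, the exchange of 5-amino-1H-1,2,4-triazol-3-yl for 5-methyl-1,3,4-thiadiazol-2-yl on a sulfur gives a 7.3-fold lower number from compound 2 to compound 3 (0.87 log units; beyond the scatter) and provides the first readable step. It shows that the read-out responds to the group at this place, even though both groups have 6 heavy atoms, 3 hydrogen-bond acceptors and one five-membered aromatic ring with 3 hetero atoms. The entering group has 0 hydrogen-bond donors where the leaving group has 2, but nothing measured here accounts for the step.

Going by these compounds, the amino group, the ring sulfur and the methyl group all change together in this single exchange, so their separate contributions remain open. A 5-amino-1,3,4-thiadiazol-2-yl group on the same sulfur would separate the amine from the ring.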